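One stereocentre changed in a pair of amides

This account rests on a few compounds, and the source may have more. Where it says the series, first, only, none or still open, it means among the compounds named here.

Measured in a functional assay on A549 cells (Homo sapiens) for cytotoxicity, read by MTT assay, with a stated time of 48 h; a lower number here means a stronger inhibitor, a higher number a weaker inhibitor:
compound 1 `CCOC(=O)[C@@]1(C(=O)Nc2ccccc2Cl)C[C@@H]1c1cc(OC)c(OC)c(OC)c1`: 29000 nM
compound 2 `CCOC(=O)[C@@]1(C(=O)NCc2ccc(C)cc2)C[C@H]1c1cc(OC)c(OC)c(OC)c1`: 17100 nM

The numbers for compound 1 and compound 2 lie within the usual scatter of repeated measurements, so these results cannot rank the two compounds. Compound 2, at 17100 nM, therefore shares its place on this small scale with compound 1.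

The next compound to be tested is compound 3 `CCOC(=O)[C@@]1(C(=O)NCc2ccc(C)cc2)C[C@@H]1c1cc(OC)c(OC)c(OC)c1`. Nothing leaves and nothing enters on going to it from compound 2: the two compounds have the same atoms and bonds and differ only in configuration as drawn: 1 of 2 stereo elements differ; a stereocentre at a saturated ring carbon is drawn S in compound 2 and R in compound 3. The two compounds have the same atoms and bonds, and a stereocentre at a saturated ring carbon is drawn S in compound 2 and R in compound 3.

Among the compounds with values here, no measured pair here isolates a change of this kind, so the size of its effect is an open question. The best available anchor is compound 2 at 17100 nM, and no shift beyond the scatter is expected. The estimated change (a 1.2-fold higher number from compound 2 to compound 3 (0.07 log units; within the scatter)) is accordingly small, though the uncertainty around it is wide. For compound 3 the expected value is 20000 nM, with an estimated range from 8000 nM to 45000 nM.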

Compound 3, half-maximal inhibitory concentration: > 100000 nM
Compound 3 gave a limit, no number (the forecaster's own chance of this, stated with the estimate: 15%); middle value at least 5.0-fold (0.69 log units) away from the limit.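

In this assay compound 3 gives > 100000 nM, which is a limit of the assay and not a number. The earlier compounds shown here differed in more than one place, whereas here the drawn change from S to R at a saturated ring carbon gives an at least 5.8-fold higher number from compound 2 to compound 3 (0.76 log units; beyond the scatter), and this step can be tied to configuration alone because of one fact: the fact that compounds 2 and 3 differ only in the configuration as drawn. With the ring drawn as in compound 3, the amide substituent also counts, since 4-methylbenzyl in place of 2-chlorophenyl on an amide-type nitrogen gives an at least 3.4-fold higher number from compound 1 to compound 3 (0.53 log units; beyond the scatter).

On these data alone, the full size of both steps stays unknown because of where the reading ends: the limit of > 100000 nM in this assay, at which 1 of the 3 values shown sits. Also open, as far as these compounds go, is whether the preference for the S drawing at this ring carbon would hold with another group on the amide nitrogen, such as a longer chain ending in an amine, or with a carboxylic acid in place of the ethyl ester.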